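Sinapate-type esters with phenethyl alcohols: ring substituent change

The source may report more compounds than this note shows. Statements on the series, on what has been measured and on what is new or still open speak of the compounds shown alone.

`COc1cc(/C=C/C(=O)OCCc2ccccc2C(F)(F)F)cc(OC)c1O` compound 1, 350 nM in an assay on PMNL cells for inhibition of Polyunsaturated fatty acid 5-lipoxygenase (Homo sapiens), read by HPLC, with stated times of 5 min and 15 min; a higher number here means a weaker inhibitor, a lower number a stronger inhibitor
`COc1cc(/C=C/C(=O)OCCc2cccc(C)c2)cc(OC)c1O` compound 2, 200 nM in this assay

Compound 2 holds the lower of the two numbers in this assay; compound 1 is its nearest neighbour, and the gap between them lies within the scatter, so no order between them is claimed. Compound 3, `COc1ccccc1CCOC(=O)/C=C/c1cc(OC)c(O)c(OC)c1`, differs from compound 2 by 2-methoxyphenyl in place of 3-methylphenyl on a saturated chain carbon, two bonds along the chain from an oxygen next to a carbonyl group. Among the compounds with values here, no measured step of this type exists. The change swaps one ring substituent for another with one acceptor added, so for compound 3 no step beyond the scatter is expected in this assay; the estimated step of a 1.3-fold higher number from compound 2 to compound 3 (0.11 log units; within the scatter) is small. Compound 3 is expected to give about 260 nM in this assay, with a range from 120 nM to 600 nM.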

Compound 3, half-maximal inhibitory concentration: 250 nM
Estimate against measurement, compound 3: 1.0-fold (0.02 log units) above; low and high end bracket the measured number.
By their numbers in this assay, from the lowest: compounds 2, 3 and 1 (each within the scatter of the next).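

In this assay 2-methoxyphenyl in place of 3-methylphenyl on a saturated chain carbon gives a 1.3-fold higher number from compound 2 to compound 3 (0.10 log units; within the scatter) and methoxy in place of trifluoromethyl on an aromatic carbon gives a 1.4-fold lower number from compound 1 to compound 3 (0.15 log units; within the scatter) in the same series. Across compounds 1, 2 and 3, then, these ring changes, including the one added acceptor of 2-methoxyphenyl, bring no step beyond the scatter. No measurement available here offers an explanation for these values.

From the compounds shown here alone, whether an amine or a carboxylic acid on the ring would bring a step beyond the scatter remains open. So does the effect of a longer chain.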